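Removing one methyl from a gem-dimethyl ring carbon

The source may report more compounds than this note shows. Statements on the series, on what has been measured and on what is new or still open speak of the compounds shown alone.

The compounds share a core in which a chlorinated bicyclic lactam carries a pyridin-3-yl group on its ring nitrogen. Compound 1 `O=C1c2ccc(Cl)cc2CN1c1cccnc1` bears hydrogen at the saturated ring carbon, and in an ADME assay on cells for inhibition of cytochrome P450 11B1, mitochondrial (Homo sapiens), read by HTRF (a higher number here means a weaker inhibitor, a lower number a stronger inhibitor), compound 1 gives 10700 nM. Compound 2 `CCC1c2cc(Cl)ccc2C(=O)N1c1cccnc1` carries an ethyl there, and in this assay compound 2 gives 3340 nM. Compound 3 `CC1(C)c2cc(Cl)ccc2C(=O)N1c1cccnc1` has two methyl groups at that carbon, and in this assay compound 3 gives 4280 nM, the second highest of the three numbers: it sits within the scatter of compound 2 but beyond the scatter of compound 1.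

Compound 4 `CC1c2cc(Cl)ccc2C(=O)N1c1cccnc1` has not yet been measured. The change from compound 3 is hydrogen in place of methyl on a saturated ring carbon. Among the compounds with values here, the only step that bears on it is a 3.2-fold lower number from compound 1 to compound 2 (0.51 log units; beyond the scatter), which shows that adding a small alkyl group at this carbon lowers the number; the two values of compound 1 and compound 3 point the same way. Compound 4 keeps one methyl, so it lies between the unsubstituted and the doubly substituted case, and the expected change a 1.3-fold higher number from compound 3 to compound 4 (0.11 log units; within the scatter) is a small rise, likely within the scatter. Compound 4 is therefore expected to give about 5500 nM in this assay, with a plausible range from 2700 nM to 11000 nM.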

Compound 4, half-maximal inhibitory concentration: 1250 nM
Beside the measured number, compound 4's estimate is 4.4-fold (0.64 log units) above it; measured number below the stated range.
By their numbers in this assay, from the lowest: compound 4; then compounds 2 and 3 (each within the scatter of the next); then compound 1.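

Placing a single methyl on this saturated ring carbon gives an 8.6-fold lower number from compound 1 to compound 4 (0.93 log units; beyond the scatter) in this assay and makes compound 4 the strongest inhibitor of the four. Going the other way, a 3.4-fold lower number from compound 3 to compound 4 (0.53 log units; beyond the scatter) comes with the loss of the second methyl, and a 2.7-fold lower number from compound 2 to compound 4 (0.43 log units; beyond the scatter) comes with shortening the ethyl to a methyl, so a larger group at this carbon does better than neither hydrogen nor methyl alone would suggest only up to the single methyl. The number therefore does not fall steadily as carbon is added at this position: it is lowest with one methyl, while the ethyl of compound 2 and the two methyl groups of compound 3 stand within the scatter of each other, higher than compound 4 yet still lower than the hydrogen of compound 1.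

The data shown offer no measured explanation for this preference for one methyl. On these data alone, whether a hydroxymethyl, a methoxy group, a fluorine or a cyclopropyl ring at this carbon would keep the number as low as the methyl does stays open, as does whether the same methyl step holds when the chlorine on the shared core gives way to another group, such as a nitrile.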